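This account rests on a few compounds, and the source may have more. Where it says the series, first, only, none or still open, it means among the compounds named here.

In a functional assay on HT cells (Homo sapiens) for antiproliferative activity, read by fluorescence, with a stated time of 72 h (a lower number here means a stronger inhibitor of growth, a higher number a weaker inhibitor of growth), three compounds have been measured:

compound 1, `CC(C)c1n[nH]c2c(NCc3ccc(-c4ccccn4)cc3)nc(SCCN)nc12`: 22 nM
compound 2, `CC(C)c1n[nH]c2c(NCc3ccc(-c4ccccn4)cc3)nc(SC[C@H](O)CN)nc12`: 63 nM
compound 3, `CC(C)c1n[nH]c2c(NCc3ccc(-c4ccccn4)cc3)nc(SCCn3ccnc3)nc12`: 155 nM

Compound 1 gives the lowest number of the three; its nearest neighbour is compound 2 and the furthest compound 3, both steps beyond the scatter. Compound 4, `CCC(O)CSc1nc(NCc2ccc(-c3ccccn3)cc2)c2[nH]nc(C(C)C)c2n1`, differs from compound 1 by 1-hydroxypropyl in place of aminomethyl on a saturated chain carbon bound to a sulfur. Among the measured compounds shown here, two measured steps bear on this change: a 2.9-fold higher number from compound 1 to compound 2 (0.46 log units; beyond the scatter) and a 7.0-fold higher number from compound 1 to compound 3 (0.85 log units; beyond the scatter), each a modest rise. Since the amine that is present in compound 1 and compound 2 is absent in compound 4, a rise of similar or somewhat larger size is expected in this assay. Compound 4 is therefore estimated at 120 nM, in the range 40 nM to 400 nM. This expected step would be a 5.5-fold higher number from compound 1 to compound 4 (0.74 log units; beyond the scatter).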

Compound 4, concentration for 50% growth inhibition: 273 nM
Compound 4: the middle estimate sits 2.3-fold (0.36 log units) below what was measured; the range from low to high includes it.
By their numbers in this assay, from the lowest: compound 1; then compound 2; then compounds 3 and 4 (each within the scatter of the next).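

Among the compounds shown here, with 1-hydroxypropyl in place of aminomethyl, the largest step so far appears in this assay: a 12-fold higher number from compound 1 to compound 4 (1.09 log units; beyond the scatter). The hydroxyl alone does not match the chain that also bears an amine, with a 4.3-fold higher number from compound 2 to compound 4 (0.64 log units; beyond the scatter). The hydroxyl chain and the 1H-imidazol-1-yl chain are not separated, with a 1.8-fold higher number from compound 3 to compound 4 (0.25 log units; within the scatter). Nothing measured here explains these steps. Open, as far as these compounds go, is how a methylamine, a dimethylamine or a carboxylic acid at the end of the same chain would compare, and whether a shorter hydroxyl chain would differ from 1-hydroxypropyl.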